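The source may report more compounds than this note shows. Statements on the series, on what has been measured and on what is new or still open speak of the compounds shown alone.

Measured in an assay on isolated protein for inhibition of leukotriene B4 receptor 1 (Homo sapiens), tested at 10 uM; on this read-out lower numbers stand for less inhibition and higher numbers for more inhibition at the one concentration tested (going by the name of the read-out):

compound 1, `C=CCc1cc(C(C)=O)c(O)cc1OCCCCCCCCCCC#N`: 50%
compound 2, `CCc1cc(C(C)=O)c(O)cc1OCCCC(C)(C)C#N`: 85%
compound 3, `C=CCc1cc(C(C)=O)c(O)cc1OCCCCCC(C)=O`: 98%

Compound 2 stands second highest of the three numbers in this assay. Its nearest neighbour is compound 3, which lies higher by a margin beyond the scatter; furthest is compound 1, well below it, also beyond the scatter.

The compound still to be measured is compound 4, `CCc1cc(C(C)=O)c(O)cc1OCCCCCCc1nnn[nH]1`. It differs from compound 2 at the end of the chain that hangs from the aromatic oxygen: 3-(1H-tetrazol-5-yl)propyl in place of 1-cyano-1-methylethyl on a saturated chain carbon, three bonds along the chain from an oxygen on an aromatic ring.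

Among the measured compounds shown here, only one measured step concerns the terminus of that chain: a number 48 percentage points higher from compound 1 to compound 3 (beyond the scatter). It shows that exchanging the group at the chain end can move the read-out by a large amount in this series. For the measured compounds named here, no measured pair, however, brings in a tetrazole ring, and no measured pair keeps the ethyl of compound 2 while altering the chain end, so the direction for compound 4 is not fixed by the data. Compound 2 already sits high, and compound 1, with a nitrile at the chain end, gives only a middling number of 50%, so a step of a number 5 percentage points lower from compound 2 to compound 4 (within the scatter) is expected, within the scatter, with wide uncertainty. For compound 4 the value in this assay is estimated at 80%, between 55% and 98%.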

Compound 4, a percentage reported as inhibition, at one concentration (the size of the read-out at that concentration, not a potency): 91%
For compound 4 the middle estimate is 11 percentage points below the measured one; low and high end bracket the measured number.
By their numbers in this assay, from the lowest: compound 1; then compounds 2, 4 and 3 (each within the scatter of the next, the first and the last beyond it).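

In this assay, 3-(1H-tetrazol-5-yl)propyl in place of 1-cyano-1-methylethyl on a saturated chain carbon, three bonds along the chain from an oxygen on an aromatic ring, gives a number 6 percentage points higher from compound 2 to compound 4 (within the scatter). Among the compounds shown here, this place therefore carries a five-membered aromatic ring with 4 hetero atoms, with 8 heavy atoms entering for 5 and a hydrogen-bond donor that the leaving group lacks, and the read-out stays within the scatter; no earlier compound holds a ring in the chain, and the only earlier step at a chain end, a number 48 percentage points higher from compound 1 to compound 3 (beyond the scatter), is large and concerns other groups. Nothing measured here bears on why these two different chain ends read alike.

Still open, on these data alone, is whether a carboxylic acid at the same chain end, or a longer chain carrying the tetrazole, would read alike with compound 4. Also open, as far as these compounds go, are how compound 2 and compound 4 compare in potency, since a single concentration gives no potency, and whether allyl can take the place of the ethyl on the core with the tetrazole chain end kept.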